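Working notes: hepatic extraction from compound 2 to compound 3

This account rests on a few compounds, and the source may have more. Where it says the series, first, only, none or still open, it means among the compounds named here.

Compound 1 `CC[C@H]1OC(=O)[C@H](C)C(=O)[C@H](C)[C@@H](O[C@@H]2O[C@H](C)C[C@H](N(C)C)[C@H]2O)[C@](C)(O)C[C@@H](C)C(=O)[C@H](C)[C@H]2N(C3CN(Cc4c(OC)cnc5ccccc45)C3)C(=O)O[C@]12C`: 0.6
Compound 2 `CC[C@H]1OC(=O)[C@H](C)C(=O)[C@H](C)[C@@H](O[C@@H]2O[C@H](C)C[C@H](N(C)C)[C@H]2O)[C@](C)(O)C[C@@H](C)C(=O)[C@H](C)[C@H]2N(C3CN(Cc4c(OC)cnc5ncccc45)C3)C(=O)O[C@]12C`: 0.8

In an ADME assay on microsomes from liver (Homo sapiens) for metabolic stability, tested at 1 uM (on this read-out higher numbers stand for higher hepatic extraction and lower numbers for lower hepatic extraction), compound 1 gives 0.6 and compound 2 gives 0.8. For the measured compounds named here, compound 2 stands highest of the two numbers, the single measured step being a number 0.20 higher from compound 1 to compound 2 (beyond the scatter). Compound 3 `CC[C@H]1OC(=O)[C@H](C)C(=O)[C@H](C)[C@@H](O[C@@H]2O[C@H](C)C[C@H](N(C)C)[C@H]2O)[C@](C)(O)C[C@@H](C)C(=O)[C@H](C)[C@H]2N(C3CN(Cc4ccnc5ncccc45)C3)C(=O)O[C@]12C` differs from compound 2 by hydrogen in place of methoxy on an aromatic carbon. That one measured step concerns the exchange of aromatic rings, not the methoxy, so it offers no direct guide to this change. A step within the scatter is therefore expected, a number 0.050 lower from compound 2 to compound 3 (within the scatter). Compound 3 is estimated at 0.75, with a range from 0.6 to 0.9.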

Compound 3, hepatic extraction ratio: 0.6
Beside the measured number, compound 3's estimate is 0.15 above it; low and high end bracket the measured number.
By their numbers in this assay, from the lowest: compounds 1 and 3 (each within the scatter of the next); then compound 2.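

In this assay, hydrogen in place of methoxy gives a number 0.20 lower from compound 2 to compound 3 (beyond the scatter) on this carbon, ortho to a large group, so the position does bear on the read-out. The full exchange of the group gives no change at the digits printed from compound 1 to compound 3 (within the scatter) at the digits printed, so the methoxy change and the ring exchange need to be read together in this series. Nothing at hand gives a cause for these steps.

On these data alone, whether an ethoxy, a fluorine or an amine on this carbon would match methoxy or hydrogen stays open. So does the size of the methoxy step on the ring system of compound 1.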